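The source may report more compounds than this note shows. Statements on the series, on what has been measured and on what is new or still open speak of the compounds shown alone.

Measured compounds:
compound 1 `Brc1cn2ccnc2c(-c2ccc3ncn(C4CCCCC4)c3c2)n1` – 14.9%
compound 2 `CC(=O)c1ccc(-c2cn3ccnc3c(-c3ccc4ncn(C5CCCCC5)c4c3)n2)cc1` – 20.8%

In a functional assay on RPMI-8226 cells (Homo sapiens) for inhibition, read by sulforhodamine B assay, with a stated time of 48 h, tested at 10 uM (on this read-out higher numbers stand for more inhibition at the one concentration tested (going by the name of the read-out) and lower numbers for less inhibition), compound 1 gives 14.9% and compound 2 gives 20.8%. Compound 2 stands at the top of these two numbers, but only by the step of a number 5.9 percentage points higher from compound 1 to compound 2 (within the scatter), which is within the scatter, so the two compounds are not truly told apart. Compound 3 `Fc1ccccc1-c1cn2ccnc2c(-c2ccc3ncn(C4CCCCC4)c3c2)n1` differs from compound 2 in one place: 2-fluorophenyl in place of 4-acetylphenyl on an aromatic carbon. The single measured step, from compound 1 to compound 2, put a 4-acetylphenyl in place of bromo and stayed within the scatter; no measured step swaps one six-membered aromatic ring of carbon only for another, so nothing shown speaks directly to this change. Going by the values given here, with the one known step in this assay being small, the step of a number 2.8 percentage points lower from compound 2 to compound 3 (within the scatter) is expected to remain within the scatter. Compound 3 is therefore estimated at 18%, within a range from 4% to 36%.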

Compound 3, a percentage reported as inhibition, at one concentration (the size of the read-out at that concentration, not a potency): 42.4%
Estimate against measurement, compound 3: 24.4 percentage points below; the whole stated range lies below it.
By their numbers in this assay, from the lowest: compounds 1 and 2 (each within the scatter of the next); then compound 3.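

In this assay the aromatic carbon next to the ring nitrogen proves sensitive to the group it carries: 2-fluorophenyl in place of 4-acetylphenyl gives a number 21.6 percentage points higher from compound 2 to compound 3 (beyond the scatter) and 2-fluorophenyl in place of bromo gives a number 27.5 percentage points higher from compound 1 to compound 3 (beyond the scatter) in a second modest rise. The step between compound 1 and compound 2 did not show this, since it stayed within the scatter. Compound 2 and compound 3 both carry a six-membered aromatic ring of carbon only here, so having such a ring at this position does not by itself set the level of inhibition, and no supporting data point to an explanation for the difference.

Open, on these data alone, is what an unsubstituted phenyl or a 4-fluorophenyl would give, which would help separate the role of the fluorine from that of its place on the ring. Also open, as far as these compounds go, is how a non-aromatic group at this carbon, such as an amine or a carboxylic acid, would compare.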